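The source may hold more compounds than are shown below. What is called first, only, known or untested is meant among the compounds shown, and "the series" means these compounds.

Measured compounds:
compound 1, `COc1cccc(OC)c1OCCNCCOc1ccccc1OCc1ccc(C)cc1`, 61700 nM
compound 2, `COc1cccc(COc2ccccc2OCCNCCOc2c(OC)cccc2OC)c1`, 61700 nM

Compound 1 and compound 2 share the same core and differ only in the group carried on a saturated chain carbon bound to an oxygen on an aromatic ring. In a functional assay on PC-3 cells (Homo sapiens) for cytotoxicity, read by sulforhodamine B assay (on this read-out higher numbers stand for lower toxicity in this test and lower numbers for higher toxicity in this test), compound 1 gives 61700 nM and compound 2 gives 61700 nM; the step of no change at the digits printed from compound 1 to compound 2 (within the scatter) lies within the scatter, so compound 2 stands level with compound 1 on this read-out.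

Compound 3, `COc1cccc(OC)c1OCCNCCOc1ccccc1OCc1ccc(OC(C)C)cc1`, is not yet measured. It differs from compound 2 by 4-isopropoxyphenyl in place of 3-methoxyphenyl on a saturated chain carbon bound to an oxygen on an aromatic ring. Among the compounds with values here, only one measured step bears on this place, the one from compound 1 to compound 2, and it showed no change in this assay beyond the scatter. On that basis compound 3 is expected to show a step of no change at the digits printed from compound 2 to compound 3 (within the scatter), that is none beyond the scatter. Compound 3 is therefore estimated at 61700 nM, with a range from 30000 nM to 125000 nM.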

Compound 3, concentration lethal to 50% of the cells: 63100 nM
For compound 3 the middle estimate is 1.0-fold (0.01 log units) below the measured one; the measured number falls inside the stated range.
By their numbers in this assay, from the lowest: compounds 1, 2 and 3 (each within the scatter of the next).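

In this assay, 4-isopropoxyphenyl in place of 3-methoxyphenyl on a saturated chain carbon bound to an oxygen on an aromatic ring gives a 1.0-fold higher number from compound 2 to compound 3 (0.01 log units; within the scatter), so a group of 10 heavy atoms replaces one of 8 with the read-out staying level. Isopropoxy in place of methyl on an aromatic carbon gives a 1.0-fold higher number from compound 1 to compound 3 (0.01 log units; within the scatter), which means that three different groups at this place now stand level, where the earlier compounds offered only two. No available data offer an explanation for this flat result.

On these data alone, all three groups are phenyl rings with no hydrogen-bond donor, so the effect of an amine or a carboxylic acid on that ring, or of a pyridine ring in its place, remains open. The compounds shown also leave open what a change to the rest of the shared core would do.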